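This account rests on a few compounds, and the source may have more. Where it says the series, first, only, none or still open, it means among the compounds named here.

Measured compounds:
compound 1, `Cc1cc2ccccc2nc1-c1cn(CCC(F)(F)C(F)(F)C(F)(F)C(F)(F)C(F)(F)C(F)(F)C(F)(F)C(F)(F)F)nn1`, gives 56.6 ug/mL in a functional assay on U-937 cells (Homo sapiens) for cytotoxicity, read by MTT assay, with a stated time of 24 h; on this read-out lower numbers stand for stronger inhibition and higher numbers for weaker inhibition.
compound 2, `CCc1cc2ccccc2nc1-c1cn(-c2ccc(F)cc2)nn1`, reaches only the limit > 100 ug/mL in this assay; this is a limit of the method, not a number.

For the measured compounds named here, compound 1 therefore holds the only numerical value recorded in this assay; the other entry is the limit of > 100 ug/mL in this assay, at which 1 of the 2 values shown sits. Going by the values given here, no two measured compounds differ in a single place, so no measured step is available to calibrate the change that follows.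

Compound 3, `CCCc1cc2ccccc2nc1-c1cn(CCC(F)(F)C(F)(F)C(F)(F)C(F)(F)C(F)(F)C(F)(F)C(F)(F)C(F)(F)F)nn1`, differs from compound 1 by ethyl in place of hydrogen on a saturated chain carbon bound to an aromatic carbon, the perfluorinated chain on the triazole being kept unchanged. Among the compounds with values here, with no measured pair of this kind, the expected step of a 1.1-fold lower number from compound 1 to compound 3 (0.05 log units; within the scatter) in this assay is small, within the usual scatter, and without a clear direction. Compound 3 is accordingly estimated at 50 ug/mL, with a range from 20 ug/mL to 100 ug/mL.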

Compound 3, half-maximal inhibitory concentration: > 100 ug/mL
Compound 3 was reported as a limit (the forecaster's own chance of this, stated with the estimate: 25%); middle value at least 2.0-fold (0.30 log units) away from the limit.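

Compound 3 reaches only a limit in this assay, > 100 ug/mL, which is a limit of the assay and not a number. The earlier compounds shown here offered no measured step, and the replacement of hydrogen by ethyl on a saturated chain carbon bound to an aromatic carbon, with the perfluorinated chain kept unchanged, now gives a first one: an at least 1.7-fold higher number from compound 1 to compound 3 (0.24 log units; that floor lies within the scatter). For the compounds shown here, this step is only a floor, so it does not show a change beyond the scatter, and compound 1 keeps the only numerical value, while the limit now accounts for most of the entries: the limit of > 100 ug/mL in this assay, at which 2 of the 3 values shown sit.

From the compounds shown here alone, the true value of compound 3 remains open, and so does the size of the step. Also open, going by these compounds, is how an amine, a carboxylic acid or a longer chain at this place would read out in this assay.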